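Chloro for cyano on the aryl arm: tolerability outlook

The source may report more compounds than this note shows. Statements on the series, on what has been measured and on what is new or still open speak of the compounds shown alone.

Within the data shown here, compound 1 `N#Cc1ccc(CN2c3ccccc3C(=O)N(Cc3ccccc3)S2(=O)=O)cc1` is the only member of the pair with a number in a functional assay on MRC5 cells (Homo sapiens); a higher number here means that more compound is tolerated, a lower number that less compound is tolerated: compound 1 gives 62000 nM. Compound 2 `O=C1c2ccccc2N(Cc2ccccc2-c2ccccc2)S(=O)(=O)N1Cc1ccccc1-c1ccccc1` is reported only as a limit, (the limit of > 47000 nM in this assay, at which 1 of the 2 values shown sits), so that compound 2 gives > 47000 nM. Compound 3 `O=C1c2ccccc2N(Cc2ccc(Cl)cc2)S(=O)(=O)N1Cc1ccccc1` is still to be measured; it differs from compound 1 by chloro in place of cyano on an aromatic carbon. Among the measured compounds shown here, with no measured step available, the step from compound 1 to compound 3 in this assay is expected to stay within the scatter, a 1.2-fold lower number from compound 1 to compound 3 (0.09 log units; within the scatter). Compound 3 is thus estimated at 50000 nM, within 20000 nM to 110000 nM.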

Compound 3, half-maximal cytotoxic concentration: 60000 nM
Compound 3: middle estimate off by 1.2-fold (0.08 log units), on the low side; measured number inside the range.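

In this assay, among these compounds, the first readable step, 4-cyanobenzyl to 4-chlorobenzyl, gives a 1.0-fold lower number from compound 1 to compound 3 (0.01 log units; within the scatter), so this aromatic carbon carries either group with no change beyond the scatter. The hydrogen-bond acceptor and triple bond that leave with the cyano group therefore make no readable difference to this number. No measured property on hand bears on this step.

Going by these compounds, what an amine or a carboxylic acid on this aromatic carbon would do in this assay stays open. Also open, on these data alone, is how a chloro or cyano group on the other benzyl arm would read.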